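Cyclopentyl on the primary amide of compound 1

The source may hold more compounds than are shown below. What is called first, only, known or untested is meant among the compounds shown, and "the series" means these compounds.

For the measured compounds named here, in a functional assay on NCI-H1975 cells (Homo sapiens) for antiproliferative activity, read by CCK-8 assay, with a stated time of 72 h (a lower number here means a stronger inhibitor of growth, a higher number a weaker inhibitor of growth), compound 1 `CC[C@@H]1C(=O)N(C)c2cnc(-n3ccc4cc(C(N)=O)ccc43)nc2N1C1CCCC1` gives 3380 nM as the lowest number of the three measured so far. Compound 3 `CCCNC(=O)c1ccc2c(ccn2-c2ncc3c(n2)N(c2ccn(C)n2)C(CC)C(=O)N3C)c1` gives 11000 nM and compound 2 `CCCNS(=O)(=O)c1ccc(Nc2ncc3c(n2)N(c2ccn(C)n2)C(CC)C(=O)N3C)cc1` gives 21700 nM in the same read-out, both gaps from compound 1 lying beyond the scatter. Compound 4 `CC[C@@H]1C(=O)N(C)c2cnc(-n3ccc4cc(C(=O)NC5CCCC5)ccc43)nc2N1C1CCCC1` differs from compound 1 by cyclopentyl in place of hydrogen on an amide-type nitrogen with cyclopentyl in place of hydrogen on an amide-type nitrogen. Going by the values given here, no measured pair isolates this change. Compound 3 also carries a substituent on its amide nitrogen but differs elsewhere too, so 11000 nM offers only a weak hint of weaker inhibition. In this assay the expected change is a 2.4-fold higher number from compound 1 to compound 4 (0.37 log units; beyond the scatter) toward a higher number, beyond the scatter. The estimated value for compound 4 is 8000 nM with an expected range from 2500 nM to 25000 nM for repeat measurements.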

Compound 4, concentration for 50% growth inhibition: 856 nM
Estimate against measurement, compound 4: 9.3-fold (0.97 log units) above; the measured number lies below the stated range.
By their numbers in this assay, from the lowest: compound 4; then compound 1; then compounds 3 and 2 (each within the scatter of the next).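

In this assay, cyclopentyl in place of hydrogen on the amide-type nitrogen gives a 3.9-fold lower number from compound 1 to compound 4 (0.60 log units; beyond the scatter), so the amide hydrogen of compound 1 is not required for growth inhibition in this series. For the compounds shown here, this is the only step here that isolates a single change, and it shows that this nitrogen accepts a ring of carbon only with a gain in inhibition. No evidence on the reason for this gain is available.

Going by these compounds, whether the gain is specific to cyclopentyl remains open. Cyclohexyl, a longer open chain or a chain ending in an amine on the same nitrogen would test this.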